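Amine exchange: diisopropylamino to 4-methylpiperazin-1-yl

The source may report more compounds than this note shows. Statements on the series, on what has been measured and on what is new or still open speak of the compounds shown alone.

Measured so far in a functional assay on SW480 cells (Homo sapiens) for antiproliferative activity, read by MTT assay, with a stated time of 48 h; on this read-out higher numbers stand for weaker inhibition and lower numbers for stronger inhibition 
- compound 1 `CC(C)=CCC[C@]1(C)/C=C/[C@@H](OC(=O)C=C(C)C)[C@](C)(O)/C=C/C(=O)/C(CN(C)C)=C\C1` gives 480 nM 
- compound 2 `CC(C)=CCC[C@]1(C)/C=C/[C@@H](OC(=O)C=C(C)C)[C@](C)(O)/C=C/C(=O)/C(CN(C(C)C)C(C)C)=C\C1` gives 750 nM 
- compound 3 `CC(C)=CCC[C@]1(C)/C=C/[C@@H](OC(=O)C=C(C)C)[C@](C)(O)/C=C/C(=O)/C(CN2CCN(C)CC2)=C\C1` awaits measurement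

Compound 2 stands within the scatter of compound 1, so these two numbers give no ranking. The change now in view, 4-methylpiperazin-1-yl in place of diisopropylamino on a saturated chain carbon bound to a double-bonded ring carbon, counts as 4-methylpiperazin-1-yl in place of diisopropylamino on a saturated chain carbon bound to a double-bonded ring carbon and leaves the shared core untouched. Among the measured compounds shown here, the only measured step bearing on it is a 1.6-fold higher number from compound 1 to compound 2 (0.19 log units; within the scatter) at the same place. For the measured compounds named here, no measured compound carries a ring there, so this guide is loose. In this assay no step beyond the scatter is expected. The expected step is a 1.4-fold lower number from compound 2 to compound 3 (0.13 log units; within the scatter) and remains an estimate. Compound 3 is estimated at 550 nM with an expected range from 250 nM to 1200 nM on this read-out.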

Compound 3, half-maximal inhibitory concentration: 800 nM
Estimate against measurement, compound 3: 1.5-fold (0.16 log units) below, and the stated range covers the measured number.
By their numbers in this assay, from the lowest: compounds 1, 2 and 3 (each within the scatter of the next).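

In this assay, a ring at this place, 4-methylpiperazin-1-yl on a saturated chain carbon bound to a double-bonded ring carbon, gives a 1.1-fold higher number from compound 2 to compound 3 (0.03 log units; within the scatter) and, set against the smallest amine in the series, a 1.7-fold higher number from compound 1 to compound 3 (0.22 log units; within the scatter). Compounds with open-chain amines alone could not show that a six-membered non-aromatic ring with 2 hetero atoms is accepted here with no step beyond the scatter, so the three amines now stand together without a ranking. No evidence is available to account for this flat result.

Going by these compounds, it remains open whether any amine nitrogen is needed at this place, which a hydroxyl group or an acetamide there would test. A morpholin-4-yl ring would separate the effect of the second ring nitrogen from that of the ring itself.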